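The source may hold more compounds than are shown below. What is called first, only, known or untested is meant among the compounds shown, and "the series" means these compounds.

Measured so far in a functional assay on Coronary artery (Bos taurus); a higher number here means that more compound is needed for the effect, a lower number that less compound is needed:
- compound 1 `CCCCCNC(=O)NCCCC/C=C\CCCCCSc1nnn[nH]1`: 3700 nM
- compound 2 `CCCCCCC(=O)N(CCCC/C=C\CCCCCCC1=NOS(=O)N1)C(C)C`: 320 nM

Compound 1 stands at the higher of these two numbers, and its gap to compound 2 lies beyond the usual scatter of repeated measurements. Compound 3 `CCCCCNC(=O)NCCCC/C=C\CCCCCCc1noc(=S)[nH]1`, not yet measured, keeps the rest of compound 1 and changes one chain end: a group of 7 heavy atoms (3 carbon, 2 nitrogen, 1 oxygen, 1 sulfur; one five-membered aromatic ring with 3 hetero atoms) in place of a group of 6 heavy atoms (1 carbon, 4 nitrogen, 1 sulfur; one five-membered aromatic ring with 4 hetero atoms), on a saturated chain carbon, five bonds along the chain from a double-bonded chain carbon. The (1H-tetrazol-5-yl)sulfanyl group leaves, and the new group sits on a saturated chain carbon, five bonds along the chain from a double-bonded chain carbon.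

Within the data shown here, no measured pair isolates this change, so any forecast is loose. Among the measured compounds shown here, the only guide is compound 2, which lacks the (1H-tetrazol-5-yl)sulfanyl group and reaches 320 nM, although it also differs from compound 1 elsewhere. A moderate move to a lower number in this assay therefore seems more likely than a move to a higher one, though a result within the scatter of compound 1 would not be surprising. The expected step is a 4.1-fold lower number from compound 1 to compound 3 (0.61 log units; beyond the scatter). For compound 3 the estimated value is 900 nM, with an expected range of 180 nM to 4500 nM.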

Compound 3, half-maximal effective concentration: 3300 nM
Beside the measured number, compound 3's estimate is 3.7-fold (0.56 log units) below it, within the range that was stated.
By their numbers in this assay, from the lowest: compound 2; then compounds 3 and 1 (each within the scatter of the next).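

Measured in this assay the exchange of the (1H-tetrazol-5-yl)sulfanyl group for the new sulfur-bearing ring gives a 1.1-fold lower number from compound 1 to compound 3 (0.05 log units; within the scatter) and so leaves the two compounds indistinguishable. Among these compounds, this is the first direct reading at this place, on a saturated chain carbon, five bonds along the chain from a double-bonded chain carbon, and it shows that a five-membered aromatic ring with 3 hetero atoms and one with 4 hetero atoms serve alike here, at least for this one pair on the shared core. No measurement is available that bears on why the two groups match in this assay.

What lies behind the lower number of compound 2 stays open, as that compound differs from compound 1 and compound 3 in more than one place, so the part played by its chain end cannot be separated from that of its other changes. As far as these compounds go, it also remains open whether a carboxylic acid at this place would match these two rings or would shift the number beyond the scatter.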